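The source may report more compounds than this note shows. Statements on the series, on what has been measured and on what is new or still open speak of the compounds shown alone.

Compound 2 `CN(/N=N/c1ccc(C#N)cc1)C(=O)NCCSc1ccc(O)cc1` gives 74 h in an ADME assay on a cell-free system (plasma, Homo sapiens) for metabolic stability, read by HPLC (on this read-out lower numbers stand for a shorter-lived compound and higher numbers for a longer-lived compound), the highest of the two numbers in hand. Compound 1 `CN(/N=N/c1ccc(C#N)cc1)C(=O)CCc1ccc(O)cc1` gives 2.99 h in this assay, a gap from compound 2 that lies beyond the usual scatter. Compound 3 `Cc1ccc(/N=N/N(C)C(=O)NCCSc2ccc(O)cc2)cc1` differs from compound 2 in a single place: methyl in place of cyano on an aromatic carbon. Among the measured compounds shown here, no measured pair shows this same change, so nothing fixes the size of its step. The expected step of a 1.5-fold lower number from compound 2 to compound 3 (0.17 log units; within the scatter) is small, and may well fall within the scatter. Compound 3 is estimated at 50 h, with a range from 20 h to 120 h.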

Compound 3, half-life: 88.5 h
Compound 3: middle estimate off by 1.8-fold (0.25 log units), on the low side; the measured number falls inside the stated range.
By their numbers in this assay, from the lowest: compound 1; then compounds 2 and 3 (each within the scatter of the next).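

Replacing cyano with methyl on this aromatic carbon, para to a large group, gives a 1.2-fold higher number from compound 2 to compound 3 (0.08 log units; within the scatter) in this assay. The read-out therefore does not separate 4-cyanophenyl from 4-methylphenyl in this pair, and the long half-life seen with compound 2 does not depend on keeping the cyano group. No measurement at hand offers an explanation for this result. From the compounds shown here alone, whether an amine, a carboxylic acid or a methoxy group at this position would leave the half-life equally undisturbed remains open. So does whether methyl in place of cyano would behave alike on the core of compound 1.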